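Cytotoxicity in CEM-SS Cells: Ester to Dimethylamide

A few compounds are considered here, and "the series" means these few. Any claim that something is new, unique, unknown or untested is made for them only; others in the source may bear on it.

Compound 1, `CCCC(=O)OCSc1ccccc1C(=O)NCC(N)=O`: > 100 uM, which is a limit of the assay
Compound 2, `CCCC(=O)OCSc1ccccc1C(=O)NCC(=O)OC`: 27.3 uM

In an ADME assay on CEM-SS cells (Homo sapiens) for cytotoxicity, read by XTT assay, with a stated time of 6 days (a higher number here means that more compound is tolerated, a lower number that less compound is tolerated), compound 2 gives 27.3 uM, the only number shown. Compound 1 sits at the limit of > 100 uM in this assay, at which 1 of the 2 values shown sits. Among the compounds with values here, the single measured step, an at least 3.6-fold lower number from compound 1 to compound 2 (0.56 log units; beyond the scatter), lowered the tolerated concentration when an ester replaced an amide. Compound 3, `CCCC(=O)OCSc1ccccc1C(=O)N(C)CC(=O)N(C)C`, differs from compound 2 by ((dimethylcarbamoyl)methyl)(methyl)amino in place of ((methoxycarbonyl)methyl)amino on a carbonyl carbon. This brings back an amide at that carbonyl, so a move back in the other direction is expected, modest in size. Compound 3 is estimated at 55 uM, between 25 uM and 100 uM. The expected step is a 2.0-fold higher number from compound 2 to compound 3 (0.30 log units; within the scatter).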

Compound 3, half-maximal toxic concentration: 57.3 uM
Estimate against measurement, compound 3: 1.0-fold (0.02 log units) below; measured number inside the range.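

In this assay, the change on this carbonyl carbon gives a 2.1-fold higher number from compound 2 to compound 3 (0.32 log units; beyond the scatter), which shows that the number can rise again with an entering group that has no hydrogen-bond donor. The other step, an at least 1.7-fold lower number from compound 1 to compound 3 (0.24 log units; that floor lies within the scatter), has a floor that cannot separate the two compounds. Compound 1 stands at a limit of the assay: the limit of > 100 uM in this assay, at which 1 of the 3 values shown sits.

The compounds shown leave open whether the rise comes from the methyl on the amino nitrogen or from the dimethylcarbamoyl end. They also leave open how a carboxylic acid or a longer chain would fare in this place.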